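Chloro in place of hydrogen on the pyridinyloxy arm

This account rests on a few compounds, and the source may have more. Where it says the series, first, only, none or still open, it means among the compounds named here.

Two compounds of the series carry a number in a physicochemical assay for lipophilicity, read by LC-MS, in phosphate buffer, measured as octanol-water partition, with a stated time of 30 min, at pH 7.4, tested at 200 mM; on this read-out lower numbers stand for lower lipophilicity and higher numbers for higher lipophilicity. Compound 1 `Cn1c(COc2cccc(C(=O)O)c2)nc2ccc(Oc3ccc4c(c3)OCC4)nc21` gives 1.4, and compound 2 `Cn1c(COc2cccc(C(=O)O)c2)nc2ccc(Oc3ccc(Cl)cn3)cc21` gives 1.2; the two values lie within the scatter of each other, so no order between compound 1 and compound 2 is read from them. Compound 3 `Cn1c(COc2cccc(C(=O)O)c2)nc2ccc(Oc3ncc(Cl)cc3Cl)cc21` has not yet been measured in this assay. Compound 3 differs from compound 2 by chloro in place of hydrogen on an aromatic carbon; the site is an aromatic carbon of a six-membered aromatic ring with one nitrogen, ortho to a large group and meta to a chloro group. Among the compounds with values here, no step between measured compounds shows this kind of change, so the expectation rests on the change itself. An upward step of a number 0.60 log units higher from compound 2 to compound 3 (beyond the scatter) in this assay is expected, beyond the scatter. Compound 3 is estimated at 1.8, with a range from 1.4 to 2.3.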

Compound 3, distribution coefficient: 1.9
Compound 3: the middle estimate sits 0.10 log units below what was measured; low and high end bracket the measured number.
By their numbers in this assay, from the lowest: compounds 2 and 1 (each within the scatter of the next); then compound 3.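

In this assay, chloro in place of hydrogen on the aromatic carbon ortho to a large group and two atoms from the ring nitrogen gives a number 0.70 log units higher from compound 2 to compound 3 (beyond the scatter). Within the data shown here, this is the first single-place step, and it shows that this position of the (5-chloropyridin-2-yl)oxy arm can carry a second chloro group with a change in the number that exceeds the scatter, though it rests on one pair alone. No measurement shown bears on the cause of this step.

Open, on these data alone, is whether a methyl, a methoxy or an amine on the same aromatic carbon would move the number in the same direction and by a similar size. Also open, as far as these compounds go, is whether chloro in place of hydrogen gives a comparable step on the same arm of another compound.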